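A few compounds are considered here, and "the series" means these few. Any claim that something is new, unique, unknown or untested is made for them only; others in the source may bear on it.

Three compounds share one core and differ only in the group on a nitrogen on an aromatic ring. In an assay on HEK cells for inhibition of serine/threonine-protein kinase TNNI3K (Homo sapiens), with stated times of 30 min and 20 min (a higher number here means a weaker inhibitor, a lower number a stronger inhibitor), compound 1 `Nc1cc(Oc2ccc(NC(=O)Nc3cccc(C(F)(F)F)c3)cc2)ncn1` gives 16 nM, compound 2 `CNc1cc(Oc2ccc(NC(=O)Nc3cccc(C(F)(F)F)c3)cc2)ncn1` gives 20 nM, and compound 3 `CC(C)(O)CNc1cc(Oc2ccc(NC(=O)Nc3cccc(C(F)(F)F)c3)cc2)ncn1` gives 50 nM, the highest of the three numbers. The change a 3.1-fold higher number from compound 1 to compound 3 (0.49 log units; beyond the scatter) and the change a 2.5-fold higher number from compound 2 to compound 3 (0.40 log units; beyond the scatter) lie beyond the scatter, whereas a 1.3-fold higher number from compound 1 to compound 2 (0.10 log units; within the scatter) does not. Compound 4 `O=C(Nc1ccc(Oc2cc(NCCO)ncn2)cc1)Nc1cccc(C(F)(F)F)c1` carries hydroxymethyl in place of 1-hydroxy-1-methylethyl on a saturated chain carbon bound to a nitrogen on an aromatic ring, which brings its side group closer to that of compound 2. For compound 4 a modest drop is expected, a 1.7-fold lower number from compound 3 to compound 4 (0.22 log units; within the scatter), because a 2.5-fold higher number from compound 2 to compound 3 (0.40 log units; beyond the scatter) accompanied the opposite direction of change. Compound 4 is therefore estimated at 30 nM in this assay, within 15 nM to 60 nM.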

Compound 4, half-maximal inhibitory concentration: 40 nM
Estimate against measurement, compound 4: 1.3-fold (0.12 log units) below, within the range that was stated.
By their numbers in this assay, from the lowest: compounds 1, 2, 4 and 3 (each within the scatter of the next, the first and the last beyond it).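

In this assay, replacing 2-hydroxy-2-methylpropyl with 2-hydroxyethyl on the nitrogen gives a 1.3-fold lower number from compound 3 to compound 4 (0.10 log units; within the scatter), so the two side chains cannot be told apart here. Compared with the unsubstituted amine, the 2-hydroxyethyl group gives a 2.5-fold higher number from compound 1 to compound 4 (0.40 log units; beyond the scatter), as the larger hydroxylated chain of compound 3 also did, whereas the comparison with the methyl group gives a 2.0-fold higher number from compound 2 to compound 4 (0.30 log units; within the scatter). No evidence is available to explain these results. From the compounds shown here alone, it remains open how a longer chain, or a chain ending in an amine or a carboxylic acid instead of the hydroxyl, would compare.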